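Methylsulfonyl in place of methylsulfanyl: outlook for compound 3

The source may hold more compounds than are shown below. What is called first, only, known or untested is meant among the compounds shown, and "the series" means these compounds.

Of the compounds shown here, two carry numbers so far. In a functional assay on CHO cells for agonist activity at Alpha-2C adrenergic receptor (Homo sapiens) (a lower number here means that less compound is needed, a higher number that more compound is needed for the effect), compound 1 `CS(=O)(=O)c1ccc(Cl)cc1NCC1=NCCN1` gives 794 nM, while compound 2 `CSc1ccc(C(F)(F)F)cc1NCC1=NCCN1` gives 7.94 nM. Compound 2 thus stands at the lowest of the two values, and compound 1 sits far above it, beyond the scatter. The two compounds differ in two places at once, so the share of either change is not resolved.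

Compound 3 `CS(=O)(=O)c1ccc(C(F)(F)F)cc1NCC1=NCCN1` keeps the trifluoromethyl group of compound 2 and differs from it only in methylsulfonyl in place of methylsulfanyl on an aromatic carbon. The same methylsulfonyl group is already present in compound 1, which stands well above compound 2 in this assay, yet compound 1 also carries chlorine where compound 2 and compound 3 carry trifluoromethyl, so the reading cannot be split into its two parts. A move toward a higher number, of moderate size and beyond the scatter, is nonetheless expected for compound 3 on the strength of how compound 1 at 794 nM compares with compound 2.

Compound 3 is expected to come in at 80 nM, within 20 nM to 400 nM. This amounts to an estimated step of a 10-fold higher number from compound 2 to compound 3 (1.00 log units; beyond the scatter).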

Compound 3, half-maximal effective concentration: < 10000 nM
Compound 3 ended at the assay's limit; the forecaster's own chance of this, stated with the estimate: 3%; the middle value does not contradict the limit.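

In this assay, within the data shown here, compound 3 gives < 10000 nM, which is a limit of the assay and not a number, so no step from compound 1 or compound 2 to compound 3 can be read. The compounds shown leave open what methylsulfonyl in place of methylsulfanyl, or trifluoromethyl in place of chloro, does alone to the number.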